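This account rests on a few compounds, and the source may have more. Where it says the series, first, only, none or still open, it means among the compounds named here.

Measured so far in an ADME assay on a cell-free system (serum, Homo sapiens) for protein binding, using equilibrium dialysis, with a stated time of 4 h, tested at 10 uM:
- compound 1 `Cc1cc2cc(NC(N[C@H]3CCCCN(CC(=O)N4CCCC4)C3=O)=C(C#N)C#N)ccc2o1`: 92%
- compound 2 `Cc1c[nH]c2c(NC(N[C@H]3CCCCN(CC(=O)N4CCCC4)C3=O)=C(C#N)C#N)cccc12`: 77%

Compound 2, at 77%, has the larger unbound fraction of the two. Compound 3 `N#CC(C#N)=C(Nc1cccc2c(Cl)c[nH]c12)N[C@H]1CCCCN(CC(=O)N2CCCC2)C1=O` differs from it by chloro in place of methyl on an aromatic carbon. Within the data shown here, the only measured step, a 2.9-fold higher unbound fraction from compound 1 to compound 2 (0.46 log units; beyond the scatter), exchanged the whole group on the amine nitrogen and was modest. Among the measured compounds shown here, no measured step isolates this smaller swap, so no shift beyond the scatter is expected in this assay. The expected change is a 1.2-fold lower unbound fraction from compound 2 to compound 3 (0.06 log units; within the scatter). For compound 3 the estimated value is 80%, with an expected range of 68% to 90%.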

Compound 3, plasma protein binding: 88%
The estimate for compound 3 lay 1.7-fold (0.22 log units) (unbound fraction) above the measured number; the measured number falls inside the stated range.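

In this assay, chloro in place of methyl on this aromatic carbon, two ring bonds from the ring nitrogen, gives a 1.9-fold lower unbound fraction from compound 2 to compound 3 (0.28 log units; within the scatter) and so does not separate from the scatter. The exchange on the amine nitrogen, now read with the 3-chloro-1H-indol-7-yl group, gives a 1.5-fold higher unbound fraction from compound 1 to compound 3 (0.18 log units; within the scatter) and also stays within the scatter, unlike a 2.9-fold higher unbound fraction from compound 1 to compound 2 (0.46 log units; beyond the scatter) with the 3-methyl-1H-indol-7-yl group. Nothing available here explains these steps. On these data alone, whether an amine or a carboxylic acid on this aromatic carbon would shift plasma protein binding beyond the scatter remains open.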